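Aryl piperazine substitution in the T-type calcium channel series

The source may report more compounds than this note shows. Statements on the series, on what has been measured and on what is new or still open speak of the compounds shown alone.

Measured so far, each in an assay on HEK293 cells for inhibition of Voltage-dependent T-type calcium channel subunit alpha-1G (Homo sapiens), read by patch clamp; a higher number here means a weaker inhibitor, a lower number a stronger inhibitor:
Compound 1 `CCCc1nc(-c2ccccc2)c(CNCCN2CCN(c3cccc(C)c3C)CC2)o1` gives 1710 nM
Compound 2 `CCCc1nc(-c2ccccc2)c(CNCCN2CCN(c3ccccc3)CC2)o1` gives 10300 nM
Compound 3 `CCCc1nc(-c2ccccc2)c(CNCCCN2CCN(c3ccc(Cl)cc3)CC2)o1` gives 1310 nM

Compound 2 stands highest of the three numbers in this assay. Among the compounds with values here, the nearest is compound 1, reached by the single change a 6.0-fold higher number from compound 1 to compound 2 (0.78 log units; beyond the scatter), so the move from 2,3-dimethylphenyl to the bare phenyl on the piperazine nitrogen costs a modest but real amount. Within the data shown here, compound 3 lies furthest away; it differs from compound 2 in two places (the chain to the piperazine and the chlorine on the aryl ring), so only its two values are compared, and no single step is separated out.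

Compound 4 `CCCc1nc(-c2ccccc2)c(CNCCN2CCN(c3ccc(OC)cc3)CC2)o1` is the next point. Its difference from compound 2 is methoxy in place of hydrogen on an aromatic carbon. Among the measured compounds shown here, the one step that bears on it, a 6.0-fold higher number from compound 1 to compound 2 (0.78 log units; beyond the scatter), shows that removing substituents from this aryl ring raises the number; compound 3, with a chlorine on the same ring, also sits well below compound 2, though its longer chain clouds that comparison. A methoxy is a different group from methyl or chlorine, so the size of the gain is uncertain. A modest downward step is expected, a 2.6-fold lower number from compound 2 to compound 4 (0.41 log units; beyond the scatter). Compound 4 is therefore estimated at 4000 nM in this assay, with a range from 1500 nM to 11000 nM.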

Compound 4, half-maximal inhibitory concentration: 9200 nM
Compound 4: the middle estimate sits 2.3-fold (0.36 log units) below what was measured; low and high end bracket the measured number.
By their numbers in this assay, from the lowest: compounds 3 and 1 (each within the scatter of the next); then compounds 4 and 2 (each within the scatter of the next).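

In this assay, methoxy on the aromatic carbon para to a large group gives no readable change from the bare phenyl (a 1.1-fold lower number from compound 2 to compound 4 (0.05 log units; within the scatter)), so compound 2 and compound 4 cannot be told apart at this position. Against the 2,3-dimethylphenyl, the 4-methoxyphenyl carries a modest cost beyond the scatter (a 5.4-fold higher number from compound 1 to compound 4 (0.73 log units; beyond the scatter)), so among these compounds, adding a group to the aryl ring does not by itself match the value of compound 1, and the ring's substitution pattern and the identity of its groups remain tied together in that comparison. Nothing available here bears on the reason for this difference.

The compounds shown leave open whether a single methyl or a chlorine in the same place on the shorter-chain compounds would behave as methoxy does, or whether a methoxy placed elsewhere on the ring would differ. Compound 3 still differs from the others in more than one place, so the separate contributions of its longer chain and its chlorine cannot be read.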